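A few compounds are considered here, and "the series" means these few. Any claim that something is new, unique, unknown or untested is made for them only; others in the source may bear on it.

Among the measured compounds shown here, compound 1 `O=C(N/N=C/c1cccc(F)c1)c1cnccn1` stands lowest of the three measured members: in an ADME assay on J774 cells (Mus musculus) for cytotoxicity, read by MTT assay, with a stated time of 48 h, tested at 100 ug/mL (on this read-out lower numbers stand for a stronger effect and higher numbers for a weaker effect at the one concentration tested), compound 1 gives 46%. Its nearest neighbour on that read-out is compound 3 `N#Cc1ccccc1/C=N/NC(=O)c1cnccn1`, which gives 75%, while compound 2 `O=C(N/N=C/c1ccccc1Br)c1cnccn1` gives 100%, the highest of the three. For the measured compounds named here, the one step among the measured compounds that changes a single group is the step of a number 25 percentage points lower from compound 2 to compound 3 (beyond the scatter), where cyano replaces bromo on an aromatic carbon. Compound 4 `N#Cc1cccc(/C=N/NC(=O)c2cnccn2)c1` differs from compound 1 by cyano in place of fluoro on an aromatic carbon. This change also brings cyano onto an aromatic carbon in place of a halogen, so the step from compound 2 to compound 3 bears on it, though the group that leaves and the place of the change differ. One therefore expects a further lowering in this assay, but a smaller one than was seen from compound 2 to compound 3, since compound 1 already sits low. The expected step is a number 8 percentage points lower from compound 1 to compound 4 (within the scatter), and for compound 4 the estimate in this assay is 38%, within a range from 20% to 60%.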

Compound 4, a percentage reported as activity, at one concentration (the size of the read-out at that concentration, not a potency): 100%
For compound 4 the middle estimate is 62 percentage points below the measured one; the whole stated range lies below it.
By their numbers in this assay, from the lowest: compound 1; then compound 3; then compounds 2 and 4 (each within the scatter of the next).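

In this assay, cyano in place of fluoro on this aromatic carbon, meta to a large group, gives a number 54 percentage points higher from compound 1 to compound 4 (beyond the scatter) and so runs opposite to the earlier cyano-for-bromo change (a number 25 percentage points lower from compound 2 to compound 3 (beyond the scatter)). Across these two pairs, cyano in place of a halogen therefore has no single direction, and the pairs differ in both the halogen that leaves and the place of the change, so the two influences cannot be separated. Nothing available explains why the direction differs between the two pairs.

Going by these compounds, it remains open whether fluoro itself is what sets compound 1 apart at this place, or whether chloro, an amine or a carboxylic acid on the same carbon would give a similarly low number. Also open, on these data alone, is how fluoro and bromo compare when each sits on the same carbon.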